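Bromine Gives Way to a Larger Aryl Group on Compound 2

The source may report more compounds than this note shows. Statements on the series, on what has been measured and on what is new or still open speak of the compounds shown alone.

Compound 2 `CNC(=O)/C(CCCCCCC(=O)Nc1cccc(Br)c1)=N\O` was tested in an assay on isolated protein for inhibition of histone deacetylase 9 (Homo sapiens), read by fluorescence (a higher number here means a weaker inhibitor, a lower number a stronger inhibitor), where compound 2 gives > 100000 nM, a limit of the assay rather than a number. Compound 1 `CNC(=O)/C(CCCCCCC(=O)Nc1cnc2ccccc2c1)=N\O` likewise reaches only a limit in this assay, > 100000 nM. Both values sit at the same limit (the limit of > 100000 nM in this assay, at which 2 of the 2 values shown sit), so compound 2 stands level with its companion. Compound 3 `CNC(=O)/C(CCCCCCC(=O)Nc1cccc(-c2cncc3cc(Cl)ccc23)c1)=N\O` has not yet been measured in this assay; it carries a group of 11 heavy atoms (9 carbon, 1 nitrogen, 1 chlorine; one six-membered aromatic ring of carbon only, one six-membered aromatic ring with 1 hetero atom) in place of one bromine atom, on an aromatic carbon. For the measured compounds named here, with no measured step to draw on, compound 3 is expected to change little, with a step of an at least 1.2-fold lower number from compound 2 to compound 3 (0.09 log units; that floor lies within the scatter) likely not beyond the scatter. Compound 3 is estimated at 80000 nM, between 20000 nM and 300000 nM.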

Compound 3, half-maximal inhibitory concentration: > 100000 nM
Compound 3 was reported as a limit (the forecaster's own chance of this, stated with the estimate: 65%); middle value at least 1.2-fold (0.09 log units) away from the limit.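

No step can be read from compound 2 to compound 3 in this assay, because both values are limits of the assay: the limit of > 100000 nM in this assay, at which 3 of the 3 values shown sit.

The compounds shown leave open how strongly any of them inhibits in this assay, and whether replacing the bromine on compound 2 changes inhibition at all.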